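One Group Exchanged on the Five-Membered Aromatic Ring

The compounds below may be only part of what the source reports. "The series", "measured", "known", "first", "only" and "open" are said of these compounds alone.

Of the compounds shown here, three have been tested so far in a functional assay on MV4-11 cells (Homo sapiens) for antiproliferative activity, read by CellTiter-Glo, with a stated time of 72 h; a higher number here means a weaker inhibitor of growth, a lower number a stronger inhibitor of growth. Compound 1 (`COCCNc1cc(-c2csc(NCC3CCOCC3)n2)c(Cl)cn1`) reads > 10000 nM, which is a limit of the assay and not a number. Compound 2 (`N[C@H]1CC[C@H](CNc2cc(-c3csc(NCC4CCOCC4)n3)c(Cl)cn2)CC1`) gives 1900 nM. Compound 3 (`COCCN[C@H]1CC[C@H](Nc2cc(-c3csc(OCC4CCOCC4)n3)c(Cl)cn2)CC1`) gives 570 nM, the lower of the two actual numbers, and it is the starting point here.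

Compound 4 (`COCCN[C@H]1CC[C@H](Nc2cc(-c3csc(NCC4CC4)n3)c(Cl)cn2)CC1`) keeps the rest of compound 3 and exchanges one group: (cyclopropylmethyl)amino in place of (oxan-4-yl)methoxy on an aromatic carbon of the five-membered aromatic ring with 1 nitrogen and 1 sulfur ((cyclopropylmethyl)amino in place of (oxan-4-yl)methoxy on an aromatic carbon).

Going by the values given here, only one measured step is available, an at least 5.2-fold lower number from compound 1 to compound 2 (0.72 log units; beyond the scatter). It shows that a single exchange can clearly move the number in this assay, but it concerns a group elsewhere on the molecule. Among the compounds with values here, no measured pair isolates the exchange made here, so the data give no direction for it. The expected result is therefore no step beyond the scatter, held with wide uncertainty. The estimated step is a 1.1-fold lower number from compound 3 to compound 4 (0.06 log units; within the scatter). For compound 4 the expected value is 500 nM, with an estimated range of 120 nM to 2500 nM.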

Compound 4, concentration for 50% growth inhibition: 740 nM
Beside the measured number, compound 4's estimate is 1.5-fold (0.17 log units) below it; measured number inside the range.
By their numbers in this assay, from the lowest: compounds 3 and 4 (each within the scatter of the next); then compound 2. At a limit, above all of these: compound 1.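

In this assay, the exchange on an aromatic carbon of the five-membered aromatic ring gives a 1.3-fold higher number from compound 3 to compound 4 (0.11 log units; within the scatter), so the two compounds cannot be told apart by this measurement. Going by these compounds alone, the earlier step showed only that a change elsewhere on the molecule can move the number; this one shows that a clearly different group can sit at this position without a step beyond the scatter. The group that leaves has 8 heavy atoms and 0 hydrogen-bond donors, the one that enters has 5 heavy atoms and 1 hydrogen-bond donor, and nothing measured here gives a reason why the number holds across that difference.

The exchange replaces the linking oxygen and the ring together, so the compounds shown cannot say whether either part matters on its own. Also open, as far as these compounds go, is how far this position stays undemanding, for example whether a free amine, a carboxylic acid or a longer straight carbon chain on this aromatic carbon would keep the number within the scatter of these two compounds.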